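Sulfur-bound benzyl change: compound 2 to compound 3

The compounds below may be only part of what the source reports. "The series", "measured", "known", "first", "only" and "open" are said of these compounds alone.

compound 1 `Cc1ccc(CSc2nc3nc(C)cc(Nc4ccc(C(=O)/C=C/c5ccc6ccccc6c5)cc4)n3n2)cc1` gives 880 nM
compound 2 `Cc1cc(Nc2ccc(C(=O)/C=C/c3ccc4ccccc4c3)cc2)n2nc(SCc3ccccc3C(F)(F)F)nc2n1` gives 1240 nM

In a functional assay on SW-620 cells (Homo sapiens) for cytotoxicity, read by MTT assay, with stated times of 4 h and 72 h, tested at 5 uM (on this read-out lower numbers stand for stronger inhibition and higher numbers for weaker inhibition), compound 2 gives 1240 nM and lies within the scatter of compound 1, so the two values cannot be ranked. The next change leads to compound 3 `Cc1cc(Nc2ccc(C(=O)/C=C/c3ccc4ccccc4c3)cc2)n2nc(SCc3ccc(Br)cc3)nc2n1` and is counted as 4-bromophenyl in place of 2-(trifluoromethyl)phenyl on a saturated chain carbon bound to a sulfur in full. It puts 4-bromophenyl in place of 2-(trifluoromethyl)phenyl on a saturated chain carbon bound to a sulfur. For the measured compounds named here, only one measured step bears on this place, and it is small: a 1.4-fold higher number from compound 1 to compound 2 (0.15 log units; within the scatter) for the exchange of 4-methylphenyl and 2-(trifluoromethyl)phenyl. No value for 4-bromophenyl exists yet, and the evidence is a single pair. Going by the values given here, no step beyond the scatter is expected in this assay because a 1.4-fold higher number from compound 1 to compound 2 (0.15 log units; within the scatter) is the only change measured at this place. The expected step is a 1.2-fold lower number from compound 2 to compound 3 (0.09 log units; within the scatter) and no firm direction is assigned to it. For compound 3 the estimated value is 1000 nM (expected range 450 nM to 2300 nM).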

Compound 3, half-maximal inhibitory concentration: 370 nM
Compound 3: the middle estimate sits 2.7-fold (0.43 log units) above what was measured; the measured number lies below the stated range.
By their numbers in this assay, from the lowest: compound 3; then compounds 1 and 2 (each within the scatter of the next).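

In this assay, the aryl group on a saturated chain carbon bound to a sulfur now produces a readable difference: 4-bromophenyl in place of 2-(trifluoromethyl)phenyl gives a modest step (a 3.4-fold lower number from compound 2 to compound 3 (0.53 log units; beyond the scatter)), whereas the earlier exchange of 4-methylphenyl and 2-(trifluoromethyl)phenyl stayed within the scatter. Bromo in place of methyl on an aromatic carbon also gives a modest step (a 2.4-fold lower number from compound 1 to compound 3 (0.38 log units; beyond the scatter)), so compound 3 has the lowest number of the three, and a change of one substituent on this aryl group is enough to separate compounds that otherwise share the core. No measurement bears on why the bromo compound gives the lower number.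

The names 2-(trifluoromethyl)phenyl and 4-bromophenyl differ in both the substituent and its number, and the compounds shown do not separate these two changes. Also open, going by these compounds, is whether the lower number is particular to bromo or would extend to a chloro or methoxy group on the same aryl ring, or whether an amine or a plain alkyl chain could take the place of the aryl group.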